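Naphthyloxy acetohydrazones: cytotoxicity notes on an aryl swap

This account rests on a few compounds, and the source may have more. Where it says the series, first, only, none or still open, it means among the compounds named here.

The series shares a naphthyloxy acetohydrazone core, with the aryl group on the carbon that carries a double bond to nitrogen varied. Compound 1 is `O=C(COc1cccc2ccccc12)N/N=C/c1ccccc1Br`; in an ADME assay on HEL cells (Homo sapiens) for cytotoxicity (on this read-out higher numbers stand for lower toxicity in this test and lower numbers for higher toxicity in this test), compound 1 gives 100 ug/mL. Compound 2 is `COc1ccc(OC)c(/C=N/NC(=O)COc2cccc3ccccc23)c1`, and in this assay compound 2 gives 56.9 ug/mL. Among the compounds with values here, compound 1 is one of only two compounds measured here, and its number and that of compound 2 are within the scatter of each other, so no order can be read from them. Compound 3 is `Cc1ccc(/C=N/NC(=O)COc2cccc3ccccc23)cc1`, not yet measured. Relative to compound 1 it carries the change (4-methylphenyl in place of 2-bromophenyl on a carbon with a double bond to nitrogen). Within the data shown here, the two measured compounds give no step of their own to lean on, and both sit at the weakly toxic end, so the step from compound 1 to compound 3 is expected to be small, a 1.1-fold lower number from compound 1 to compound 3 (0.05 log units; within the scatter), none beyond the scatter. For compound 3 in this assay a value of 90 ug/mL is estimated, within a range from 40 ug/mL to 200 ug/mL.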

Compound 3, half-maximal cytotoxic concentration: 80.1 ug/mL
Compound 3: the middle estimate sits 1.1-fold (0.05 log units) above what was measured; measured number inside the range.
By their numbers in this assay, from the lowest: compounds 2, 3 and 1 (each within the scatter of the next).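

Within the data shown here, the change to 4-methylphenyl in place of 2-bromophenyl on a carbon with a double bond to nitrogen gives the first one-place step, a 1.2-fold lower number from compound 1 to compound 3 (0.10 log units; within the scatter), in this assay. For this pair, the exchange of one substituted phenyl group for another, with the same count of heavy atoms and no hydrogen-bond donors or acceptors on either side, leaves the read-out within the scatter; the group and its place on the ring change together, so this single step cannot separate the two. No measured evidence on the compounds bears on this result.

On these data alone, whether a phenyl group carrying an amine or a carboxylic acid would give a step beyond the scatter at this position remains open. As far as these compounds go, it is equally open whether a longer alkyl chain in place of the phenyl ring would leave the number within the scatter of compound 1, so the limits of what this position accepts in this test are still undefined.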